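Octyloxyphenyl tetrazole series: stability in liver S9 fraction

The source may report more compounds than this note shows. Statements on the series, on what has been measured and on what is new or still open speak of the compounds shown alone.

Working notes on a small set sharing the octyloxyphenyl ketone core, read in an ADME assay on S9 fraction from liver (Rattus norvegicus) for metabolic stability, read by LC-MS, using NADPH, with a stated time of 30 min; a lower number here means that less of the compound is left, a higher number that more of the compound is left. Two compounds have been run. Compound 1 `CCCCCCCCc1ccc(OCC(=O)Cn2nnc(CCC(=O)O)n2)cc1` carries a propanoic acid on the tetrazole and sits at the assay limit, giving < 5% in this assay, a limit rather than a number. Among the compounds with values here, compound 2 `CCCCCCCCc1ccc(OCC(=O)Cn2nnnc2-c2ccc(S(=O)(=O)N(C)C)cc2)cc1` carries a 4-(dimethylsulfamoyl)phenyl on the ring carbon and gives 40% in this assay, which is the only actual number in the set so far. The value of compound 1 is a limit, recorded as the limit of < 5% in this assay, at which 1 of the 2 values shown sits. Within the data shown here, no two measured compounds differ in one place, so no single measured step is available to calibrate the next change.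

Compound 3 `CCCCCCCCc1ccc(OCC(=O)Cn2nnnc2C(=O)OCC)cc1` is the next candidate and is not yet measured. The change from compound 2 is ethoxycarbonyl in place of 4-(dimethylsulfamoyl)phenyl on an aromatic carbon. In this assay the step from compound 2 to compound 3 is expected to be a drop, with the ethoxycarbonyl compound losing more than its predecessor: the expected step is a number 20 percentage points lower from compound 2 to compound 3 (beyond the scatter). For compound 3 the estimate in this assay is 20%, with a range from 5% to 45%.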

Compound 3, percent of the compound remaining: 33%
The estimate for compound 3 lay 13 percentage points below the measured number, and the stated range covers the measured number.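

In this assay the series now has its first readable step, a number 7 percentage points lower from compound 2 to compound 3 (within the scatter), and it places compound 2 and compound 3 level with each other. On this aromatic carbon, between two ring nitrogen atoms, the ringless ethoxycarbonyl therefore reads the same as the larger 4-(dimethylsulfamoyl)phenyl, so the six-membered aromatic ring of the group that leaves is not required for a read-out at this level. No measured property in hand accounts for the two groups reading alike.

Compound 1 stays a limit at < 5%, and it differs from compound 2 and compound 3 in more than one place, so steps to it cannot be read. Still open, from the compounds shown here alone, is how far this tolerance at the aromatic carbon extends, since a carboxylic acid, an amide or a plain ethyl chain there would show whether the level holds across other groups, and a shorter chain in place of the octyl would show what the rest of the shared core contributes.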